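The compounds below may be only part of what the source reports. "The series", "measured", "known", "first", "only" and "open" are said of these compounds alone.

Measured compounds:
compound 1 `C[C@@H]1O[C@@H](n2c3ccccc3c3c4c(c5c6ccccc6ccc5c32)C(=O)NC4=O)[C@H](O)[C@H](O)[C@H]1O`: 2700 nM
compound 2 `O=C1NC(=O)c2c1c1c3ccccc3ccc1c1c2c2ccccc2n1[C@@H]1O[C@H](CO)[C@@H](O)[C@H]1O`: 2400 nM

In a functional assay on PC-3 cells (Homo sapiens) for cytotoxicity (on this read-out lower numbers stand for stronger inhibition and higher numbers for weaker inhibition), compound 1 gives 2700 nM and compound 2 gives 2400 nM. Within the data shown here, compound 2 thus holds the lower of the two numbers, yet the only step between them, a 1.1-fold lower number from compound 1 to compound 2 (0.05 log units; within the scatter), does not separate the two compounds beyond the scatter, so neither can be called the more potent.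

Compound 3 `O=C1NC(=O)c2c1c1c3ccccc3ccc1c1c2c2ccccc2n1[C@H]1C[C@H](O)[C@@H](CO)O1` carries the shared core of compound 2 and differs from it in the sugar: hydrogen in place of hydroxy on a saturated ring carbon. Among the measured compounds shown here, no measured step removes a hydroxy from the sugar, so the closest guide is the exchange of one sugar for another, a 1.1-fold lower number from compound 1 to compound 2 (0.05 log units; within the scatter), which left the number in this assay essentially unchanged. On that basis a loss of one hydroxy from the five-membered ring is expected to move the read-out little, with a 1.2-fold lower number from compound 2 to compound 3 (0.08 log units; within the scatter) as the expected step, most likely within the scatter. For the measured compounds named here, compound 3 is therefore estimated at 2000 nM, with a range from 700 nM to 6000 nM, the width reflecting that only one sugar-change step is available.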

Compound 3, half-maximal inhibitory concentration: 2600 nM
Estimate against measurement, compound 3: 1.3-fold (0.11 log units) below; low and high end bracket the measured number.
By their numbers in this assay, from the lowest: compounds 2, 3 and 1 (each within the scatter of the next).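

Among these compounds, replacing the hydroxy on the saturated ring carbon of the five-membered ring with hydrogen, at the place next to the ring atom that bears a large group, gives a 1.1-fold higher number from compound 2 to compound 3 (0.03 log units; within the scatter) in this assay, the first direct reading of this position, and the number stays within the scatter without that hydroxy. The 4-hydroxy-5-(hydroxymethyl)oxolan-2-yl group also cannot be told apart from the 3,4,5-trihydroxy-6-methyloxan-2-yl group, with a 1.0-fold lower number from compound 1 to compound 3 (0.02 log units; within the scatter), so none of the three sugars on the aromatic nitrogen separates from the others in this assay. No independent measurement bears on this result, and the numbers alone do not say why the read-out holds.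

Still open, as far as these compounds go, is whether any group at this ring carbon can move the number beyond the scatter, such as an amine or a fluorine in place of the hydroxy. From the compounds shown here alone, it is equally open what a carboxylic acid in place of the hydroxymethyl group, or a longer chain on the aromatic nitrogen in place of the sugar, would do to the cytotoxicity of the shared core.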